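Swapping Hydroxymethyl for Isopropyl on a Shared Core

A few compounds are considered here, and "the series" means these few. Any claim that something is new, unique, unknown or untested is made for them only; others in the source may bear on it.

Three compounds have been measured in an assay on microsomes from liver for inhibition of acyl-CoA desaturase 1 (Rattus norvegicus); on this read-out higher numbers stand for weaker inhibition and lower numbers for stronger inhibition:
compound 1, `OCc1nnc(-c2ccc(N3CCC(Oc4ccccc4C(F)(F)F)CC3)nn2)s1`, gives 3.2 nM
compound 2, `FC(F)(F)c1cccc(OC2CCN(c3ccc(-n4ccnc4)nn3)CC2)c1`, gives 19 nM
compound 3, `c1cn(-c2ccc(N3CCC(Oc4ccc5c(c4)CCC5)CC3)nn2)cn1`, gives 62 nM

Among these three numbers compound 1 stands lowest, which on this read-out means the strongest inhibition. Compound 2 comes nearest to it, yet its number is higher by a margin beyond the usual scatter of repeated measurements, and compound 3 lies further away still. No two of the measured compounds differ in just one place, so no single change can be read off directly from the numbers.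

Compound 4, `CC(C)c1nnc(-c2ccc(N3CCC(Oc4ccccc4C(F)(F)F)CC3)nn2)s1`, is built from compound 1 by one change: isopropyl in place of hydroxymethyl on an aromatic carbon. Among the measured compounds shown here, nothing among the measured compounds shows what this exchange does, so the expectation rests on compound 1 alone. The step of a 1.6-fold higher number from compound 1 to compound 4 (0.19 log units; within the scatter) is expected to be small, most likely not beyond the scatter, with the direction uncertain. Compound 4 is therefore estimated at 5 nM, within a range from 1.5 nM to 20 nM.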

Compound 4, half-maximal inhibitory concentration: 8.8 nM
The estimate for compound 4 lay 1.8-fold (0.25 log units) below the measured number, within the range that was stated.
By their numbers in this assay, from the lowest: compound 1; then compound 4; then compound 2; then compound 3.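

Among the compounds shown here, compound 1 and compound 4 differ in one place only, so this is the first change whose effect can be read directly. In this assay, isopropyl in place of hydroxymethyl on the aromatic carbon gives a 2.8-fold higher number from compound 1 to compound 4 (0.44 log units; beyond the scatter) and so a modest loss of inhibition, showing that this position responds to the exchange but that activity survives without the hydrogen-bond donor and acceptor of hydroxymethyl. No independent measurement bears on why the number moved.

This single exchange removes the donor and acceptor and also changes the heavy-atom count, so it cannot tell these differences apart. As far as these compounds go, whether an aminomethyl group, a carboxylic acid or a longer alkyl chain at this position would bring the number closer to that of compound 1 or move it further away remains open.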